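This account rests on a few compounds, and the source may have more. Where it says the series, first, only, none or still open, it means among the compounds named here.

Of the compounds shown here, two built on one shared core have been measured, differing only in the aryl group attached to an amide-type nitrogen. In a functional assay on MGC-803 cells (Homo sapiens) for inhibition, read by MTT assay, with a stated time of 72 h (on this read-out higher numbers stand for weaker inhibition and lower numbers for stronger inhibition), compound 1 `O=C(CSc1nc(Nc2ccccc2)c2ccccc2n1)Nc1ccccc1F` gives 10700 nM. In this assay compound 2 `C=CC(=O)Nc1cccc(NC(=O)CSc2nc(Nc3ccccc3)c3ccccc3n2)c1` gives 7310 nM, the lowest of the two numbers shown, though the only measured step, a 1.5-fold lower number from compound 1 to compound 2 (0.17 log units; within the scatter), lies within the scatter, so the two compounds cannot be told apart on these numbers. Compound 3 `CCc1ccc(NC(=O)CSc2nc(Nc3ccccc3)c3ccccc3n2)cc1` is not yet measured; it carries 4-ethylphenyl in place of 3-((vinylcarbonyl)amino)phenyl on an amide-type nitrogen. Among the measured compounds shown here, the one step that bears on this change, the earlier swap of the aryl group from compound 1 to compound 2, was within the scatter, so no movement beyond the scatter is expected for compound 3, and the estimated step is a 1.2-fold higher number from compound 2 to compound 3 (0.09 log units; within the scatter). For compound 3 the expected value in this assay is 9000 nM, with a range from 3000 nM to 27000 nM.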

Compound 3, half-maximal inhibitory concentration: > 50000 nM
Compound 3 ended at the assay's limit; the forecaster's own chance of this, stated with the estimate: 10%; at least 5.5-fold (0.74 log units) between middle value and limit.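

In this assay compound 3 gives > 50000 nM, which is a limit of the assay and not a number. The aryl group on the amide-type nitrogen, which the first swap could not show to matter, does make a difference: 4-ethylphenyl brings an at least 6.8-fold higher number from compound 2 to compound 3 (0.83 log units; beyond the scatter), and also an at least 4.6-fold higher number from compound 1 to compound 3 (0.66 log units; beyond the scatter), so inhibition is weaker with this group than with either earlier one. Both steps give only a smallest size because compound 3 sits at a limit: the limit of > 50000 nM in this assay, at which 1 of the 3 values shown sits.

As far as these compounds go, what remains open is whether the ethyl chain itself drives this weakening, or whether any group without the amide of 3-((vinylcarbonyl)amino)phenyl or the fluorine of 2-fluorophenyl would do the same. A plain phenyl, or a phenyl carrying a methoxy group or a carboxylic acid, at this nitrogen would help to separate these possibilities.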